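A few compounds are considered here, and "the series" means these few. Any claim that something is new, unique, unknown or untested is made for them only; others in the source may bear on it.

Measured in a functional assay (aorta) for inhibition, with Rattus norvegicus as the target (a lower number here means a stronger inhibitor, a higher number a weaker inhibitor), as follows

compound 1 `CC/N=C(\S)[C@]1(c2cccnc2)CCCC[S+]1[O-]` - 300 nM
compound 2 `CCC/N=C(\S)[C@]1(c2cccnc2)CCCC[S+]1[O-]` - 600 nM
compound 3 `CCCC/N=C(\S)[C@]1(c2cccnc2)CCCC[S+]1[O-]` - 8000 nM

Compound 3 (8000 nM) stands highest of the three, beyond the scatter from both others. Compound 4 (`COC(=O)CC/N=C(\S)[C@]1(c2cccnc2)CCCC[S+]1[O-]`) has methoxycarbonyl in place of ethyl on a saturated chain carbon, two bonds along the chain from a double-bonded nitrogen.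

For the measured compounds named here, three steps bear on this: the large ethyl step at that same place (a 27-fold higher number from compound 1 to compound 3 (1.43 log units; beyond the scatter)), the large methyl step three bonds along the chain (a 13-fold higher number from compound 2 to compound 3 (1.12 log units; beyond the scatter)), and the methyl step two bonds along (a 2.0-fold higher number from compound 1 to compound 2 (0.30 log units; within the scatter)), which is within the scatter. Going by the values given here, no measured compound carries methoxycarbonyl, so only part of the ethyl step is expected to be reversed, and with wide uncertainty. The expected change is modest and towards a lower number (a 2.7-fold lower number from compound 3 to compound 4 (0.43 log units; beyond the scatter)). The estimated value for compound 4 is 3000 nM, with an expected range from 500 nM to 18000 nM.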

Compound 4, concentration for 90% inhibition: > 30000 nM
Compound 4 ended at the assay's limit (the forecaster's own chance of this, stated with the estimate: 10%); middle value at least 10-fold (1.00 log units) away from the limit.
By their numbers in this assay, from the lowest: compounds 1 and 2 (each within the scatter of the next); then compound 3. At a limit, above all of these: compound 4.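

In this assay compound 4 gives a limit rather than a number: the limit of > 30000 nM in this assay, at which 1 of the 4 values shown sits. Methoxycarbonyl at this place therefore does not recover what ethyl lost, and the result goes further in the same direction, with an at least 3.7-fold higher number from compound 3 to compound 4 (0.57 log units; beyond the scatter). Against the smaller groups the gap is wider, with an at least 50-fold higher number from compound 2 to compound 4 (1.69 log units; beyond the scatter) and an at least 100-fold higher number from compound 1 to compound 4 (2.00 log units; beyond the scatter).

As far as these compounds go, how far compound 4 lies beyond its limit stays unknown. Also open, from the compounds shown here alone, is whether a carboxylic acid or an amine at this place would fare better than methoxycarbonyl.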